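This account rests on a few compounds, and the source may have more. Where it says the series, first, only, none or still open, it means among the compounds named here.

Compound 1 `O=C(Nc1cccc(-n2cc(-c3ccncc3)c(-c3ccc(Cl)c(O)c3)n2)c1)Nc1cccc(C(F)(F)F)c1`: in a functional assay on SK-MEL-2 cells (Homo sapiens) for inhibition, read by sulforhodamine B assay, with a stated time of 48 h (on this read-out higher numbers stand for lower toxicity in this test and lower numbers for higher toxicity in this test), compound 1 sits at a limit of the assay, > 32500 nM.
Compound 2 `COc1cc(-c2nn(-c3cccc(NC(=O)c4cccc(C(F)(F)F)c4)c3)cc2-c2ccncc2)ccc1Cl`: in this assay compound 2 likewise sits at a limit of the assay, > 50000 nM.
Compound 3 `COc1cc(-c2nn(-c3cccc(NC(=O)Nc4cccc(C(F)(F)F)c4)c3)cc2-c2ccncc2)ccc1Cl`: in this assay compound 3 gives 3960 nM.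

Within the data shown here, compound 3 thus holds the only number among the three measured compounds; the values of compound 1 and compound 2 are limits (the limit of > 32500 nM in this assay, at which 1 of the 3 values shown sits, (the limit of > 50000 nM in this assay, at which 1 of the 3 values shown sits)). Compound 4 `COc1cc(-c2nn(-c3cccc(NC(=O)c4ccccc4)c3)cc2-c2ccncc2)ccc1Cl` differs from compound 3 in one place: phenyl in place of (3-(trifluoromethyl)phenyl)amino on a carbonyl carbon. Among the measured compounds shown here, two measured steps bear on this. The step from compound 1 to compound 3, an at least 8.2-fold lower number from compound 1 to compound 3 (0.91 log units; beyond the scatter), concerns the other end of the molecule and shows only that the methoxy setting shared by compound 3 and compound 4 is the better one. The step from compound 2 to compound 3, an at least 12-fold lower number from compound 2 to compound 3 (1.10 log units; beyond the scatter), is the closer guide: it shows what the urea linkage brought over the amide linkage carrying the same trifluoromethylphenyl. For the measured compounds named here, compound 4 reverses that, returning to an amide, and drops the trifluoromethyl as well, a change for which no measured step exists. The step from compound 3 to compound 4 is therefore expected to raise the number, a 10-fold higher number from compound 3 to compound 4 (1.00 log units; beyond the scatter), probably back toward the limit. Compound 4 is expected to give 40000 nM, within 10000 nM to 120000 nM, with a fair chance that only a limit is reported.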

Compound 4, concentration lethal to 50% of the cells: > 100000 nM
Compound 4: a limit, no number (the forecaster's own chance of this, stated with the estimate: 65%); middle value at least 2.5-fold (0.39 log units) away from the limit.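

Setting phenyl in place of (3-(trifluoromethyl)phenyl)amino on the carbonyl carbon gives an at least 25-fold higher number from compound 3 to compound 4 (1.40 log units; beyond the scatter), which shows that the number seen for compound 3 in this assay does not survive this change, one that removes the urea linkage and the trifluoromethyl together. Compound 2 and compound 4 both stand at limits, and the step between them, hydrogen in place of trifluoromethyl on an aromatic carbon, cannot be read, so the amide pair gives no size for what the trifluoromethyl contributes. The value of compound 4 is a limit, and compound 3 stays the only one of the four compounds with a number: the limit of > 100000 nM in this assay, at which 1 of the 4 values shown sits.

Going by these compounds, the step from compound 3 to compound 4 changes the linkage and the trifluoromethyl at once, so it remains open how much of it belongs to each, and a urea carrying plain phenyl would be needed to separate them. Also open, on these data alone, is what an amine, a carboxylic acid or a longer chain in place of the trifluoromethyl would give on the urea of compound 3.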